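A 4-fluorophenyl swap on the sulfonyl sulfur

A few compounds are considered here, and "the series" means these few. Any claim that something is new, unique, unknown or untested is made for them only; others in the source may bear on it.

In a functional assay on HL-60 cells (Homo sapiens) for cytotoxicity, read by MTT assay (on this read-out lower numbers stand for stronger inhibition and higher numbers for weaker inhibition), compound 1 `Cc1ccccc1S(=O)(=O)NC(C1=CC(=O)c2c(O)ccc(O)c2C1=O)C(C)C` gives 190 nM, and compound 2 `Cc1ccccc1S(=O)(=O)NC(C)C1=CC(=O)c2c(O)ccc(O)c2C1=O` gives 70 nM. Going by the values given here, compound 2 therefore holds the lower of the two numbers so far. Among the compounds with values here, the one measured step, a 2.7-fold lower number from compound 1 to compound 2 (0.43 log units; beyond the scatter), is modest but beyond the usual scatter. It replaces isopropyl with methyl on a saturated chain carbon bound to a double-bonded ring carbon and a sulfonamide nitrogen.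

Compound 3 `CC(NS(=O)(=O)c1ccc(F)cc1)C1=CC(=O)c2c(O)ccc(O)c2C1=O` leaves that chain as it is in compound 2 and changes a different place, with 4-fluorophenyl in place of 2-methylphenyl on a sulfonyl sulfur. Within the data shown here, no measured step touches the group on the sulfonyl sulfur, so the data offer no direct guide to this change. The step to compound 2 bears on it only indirectly, showing that a single change elsewhere in this series moved this assay by a modest amount. No shift beyond the scatter is therefore expected, and the estimated change is a 1.1-fold higher number from compound 2 to compound 3 (0.06 log units; within the scatter). For compound 3 the estimate is 80 nM, with an expected range from 30 nM to 200 nM.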

Compound 3, half-maximal inhibitory concentration: 90 nM
Beside the measured number, compound 3's estimate is 1.1-fold (0.05 log units) below it, within the range that was stated.
By their numbers in this assay, from the lowest: compounds 2 and 3 (each within the scatter of the next); then compound 1.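

Going by these compounds alone, the step at the sulfonyl sulfur, a 1.3-fold higher number from compound 2 to compound 3 (0.11 log units; within the scatter), is the first measured evidence on this position, and it shows that in this assay 4-fluorophenyl can take the place of 2-methylphenyl with no shift beyond the scatter, at least with the methyl-bearing chain of compound 2. The chain change, a 2.7-fold lower number from compound 1 to compound 2 (0.43 log units; beyond the scatter), therefore remains the only step shown here that lies beyond the scatter, so this series has so far responded measurably at the chain but not at the sulfonyl sulfur. No measured evidence accounts for either result.

The single swap removes a methyl group and introduces a fluorine together, so the compounds shown cannot separate what each contributes, and a plain phenyl group would be needed to divide the step into two parts. They also leave open whether the same tolerance holds with the isopropyl chain of compound 1, or for groups on the sulfonyl sulfur that differ more sharply from these two, such as a pyridine ring, a naphthalene ring or a simple methyl group.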